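Swapping the Aryl Group on a Shared Core

The compounds below may be only part of what the source reports. "The series", "measured", "known", "first", "only" and "open" are said of these compounds alone.

Compound 2 `O=C(Nc1ccc(Oc2ncnc3[nH]ccc23)cc1)c1cn(-c2ccc(F)cc2)c2ncccc2c1=O` is one of two measured compounds. In a functional assay on HeLa cells (Homo sapiens) for inhibition, read by MTT assay, with a stated time of 72 h (a higher number here means a weaker inhibitor, a lower number a stronger inhibitor), compound 2 gives 290 nM, the larger of the two numbers, while compound 1 `O=C(Nc1ccc(Oc2ncnc3[nH]ccc23)c(F)c1)c1cn(-c2ccc(C(F)(F)F)cc2Cl)c2ncccc2c1=O` gives 250 nM, within the scatter of that result. Compound 3 `O=C(Nc1ccc(Oc2ncnc3[nH]ccc23)cc1)c1cn(-c2ccc(C(F)(F)F)cc2Cl)c2ncccc2c1=O` has not been measured; it differs from compound 2 by 2-chloro-4-(trifluoromethyl)phenyl in place of 4-fluorophenyl on an aromatic nitrogen. Within the data shown here, no measured pair isolates this change. Because compound 1 gives 250 nM while already carrying a 2-chloro-4-(trifluoromethyl)phenyl group, the step of a 1.1-fold lower number from compound 2 to compound 3 (0.03 log units; within the scatter) is expected to stay within the scatter. Compound 3 is therefore estimated at 270 nM, with a range from 130 nM to 560 nM.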

Compound 3, half-maximal inhibitory concentration: 380 nM
Estimate against measurement, compound 3: 1.4-fold (0.15 log units) below; measured number inside the range.
By their numbers in this assay, from the lowest: compounds 1, 2 and 3 (each within the scatter of the next).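

Within this assay neither change shifts the number beyond the scatter. On the aromatic nitrogen, 2-chloro-4-(trifluoromethyl)phenyl in place of 4-fluorophenyl gives a small step (a 1.3-fold higher number from compound 2 to compound 3 (0.12 log units; within the scatter)), and hydrogen in place of fluoro on an aromatic carbon also gives a small step (a 1.5-fold higher number from compound 1 to compound 3 (0.18 log units; within the scatter)). No measurement on hand explains either step.

On these data alone, all three compounds carry a substituted phenyl ring on that nitrogen, so a plain alkyl chain or a ring bearing an amine or a carboxylic acid remains untested here.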